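This account rests on a few compounds, and the source may have more. Where it says the series, first, only, none or still open, it means among the compounds named here.

In a functional assay on MCF7 cells (Homo sapiens) for antiproliferative activity, read by MTT assay, with stated times of 24 h and 72 h (a higher number here means a weaker inhibitor, a lower number a stronger inhibitor), compound 1 `COc1cc(N2C(=O)[C@@H](Oc3ccccc3)[C@H]2c2ccc(Br)cc2)cc(OC)c1OC` gives 48000 nM. Compound 2 `COc1cc([C@@H]2[C@H](Oc3ccccc3)C(=O)N2c2cc(OC)c(OC)c(OC)c2)ccc1O` gives 32000 nM. Compound 3 `COc1cc(N2C(=O)[C@@H](Oc3ccccc3)[C@H]2c2cc(O)c(OC)c([N+](=O)[O-])c2)cc(OC)c1OC` gives 69000 nM, which places it level with compound 1 within the scatter and on the higher side of compound 2.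

Compound 4 `COc1cc([N+](=O)[O-])c([C@@H]2[C@H](Oc3ccccc3)C(=O)N2c2cc(OC)c(OC)c(OC)c2)cc1O` has the same atoms as compound 3, joined differently: a group of 12 heavy atoms (7 carbon, 1 nitrogen, 4 oxygen; one six-membered aromatic ring of carbon only) in place of a group of 12 heavy atoms (7 carbon, 1 nitrogen, 4 oxygen; one six-membered aromatic ring of carbon only), on a saturated ring carbon. Among the measured compounds shown here, no measured step covers this exact exchange. The closest evidence comes from the three exchanges of groups on this saturated ring carbon: a 1.5-fold lower number from compound 1 to compound 2 (0.18 log units; within the scatter), a 1.4-fold higher number from compound 1 to compound 3 (0.16 log units; within the scatter) and a 2.2-fold higher number from compound 2 to compound 3 (0.33 log units; beyond the scatter). Two of these lie within the scatter, and the third is only modest. In this assay, therefore, no step beyond the scatter is expected in either direction. The estimated change is a 1.2-fold lower number from compound 3 to compound 4 (0.06 log units; within the scatter). Compound 4 is expected to give about 60000 nM, with an estimated range from 25000 nM to 130000 nM.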

Compound 4, half-maximal inhibitory concentration: 59000 nM
Compound 4: the middle estimate sits 1.0-fold (0.01 log units) above what was measured; the range from low to high includes it.
By their numbers in this assay, from the lowest: compounds 2, 1, 4 and 3 (each within the scatter of the next, the first and the last beyond it).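

Among the compounds shown here, the step of a 1.2-fold lower number from compound 3 to compound 4 (0.07 log units; within the scatter) in this assay shows that joining the same atoms differently within the group on the saturated ring carbon, a kind of change absent from the earlier compounds, does not carry the number beyond the scatter. The new group also stays within the scatter of both other groups at this position, with the steps of a 1.8-fold higher number from compound 2 to compound 4 (0.27 log units; within the scatter) and a 1.2-fold higher number from compound 1 to compound 4 (0.09 log units; within the scatter), whereas the step from compound 2 to compound 3 lies just beyond it, so that this one gap does not carry over to the rearranged group. Nothing shown accounts for how closely these groups read.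

The compounds shown leave open whether an aromatic ring is needed at this position at all, as a carboxylic acid or an amine on a longer chain would test. They also leave open what exchanging the phenoxy group or the 3,4,5-trimethoxyphenyl group would do.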